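Swapping chloro for nitro on a dimethylphenyl ketone

A few compounds are considered here, and "the series" means these few. Any claim that something is new, unique, unknown or untested is made for them only; others in the source may bear on it.

Compound 1 `Cc1ccc(C(=O)CCc2nnc(-c3ccc(Cl)cc3)o2)cc1` is the starting point of this small series. In a functional assay on the whole organism (strain Wistar) for inhibition, with Rattus norvegicus as the target, with stated times of 30 min and 3 h, at a dose of 20 mg/kg by the oral route (a lower number here means less inhibition, a higher number more inhibition at the dose given (going by the name of the read-out)), compound 1 gives 81.5%. Compound 2 `Cc1ccc(C(=O)CCc2nnc(-c3ccc([N+](=O)[O-])cc3)o2)cc1` carries a single difference from compound 1, namely (nitro in place of chloro on an aromatic carbon), and in this assay compound 2 gives 60.5%. This change produced a number 21 percentage points lower from compound 1 to compound 2 (beyond the scatter).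

Compound 3 `Cc1ccc(C(=O)CCc2nnc(-c3ccc(Cl)cc3)o2)c(C)c1` differs from compound 1 by methyl in place of hydrogen on an aromatic carbon. In this assay compound 3 gives 72.6%, which amounts to a number 8.9 percentage points lower from compound 1 to compound 3 (within the scatter). Compound 3 and compound 1 are therefore read as equivalent within the usual spread of this measurement, while compound 2 stands apart from both of them.

Compound 4 `Cc1ccc(C(=O)CCc2nnc(-c3ccc([N+](=O)[O-])cc3)o2)c(C)c1` has not yet been measured. It is related to compound 3 in the same way that compound 2 is related to compound 1: the difference is nitro in place of chloro on an aromatic carbon, and the surroundings of the exchange, para to a large group on the ring, are the same in both pairs. The two cores differ only by methyl in place of hydrogen on an aromatic carbon. On that basis compound 4 is expected to show a number 20.6 percentage points lower from compound 3 to compound 4 (beyond the scatter) in this assay, a step of about the size seen as a number 21 percentage points lower from compound 1 to compound 2 (beyond the scatter). Compound 4 is thus estimated at 52%, with a plausible range from 36% to 66%.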

Compound 4, a percentage reported as inhibition, in the whole organism at one dose (the size of the read-out at that dose, not a potency): 69.1%
Compound 4: the middle estimate sits 17.1 percentage points below what was measured; measured number above the stated range.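

In this assay, on the core that carries the extra methyl, nitro in place of chloro gave a number 3.5 percentage points lower from compound 3 to compound 4 (within the scatter), so the size of this exchange depends on the core that carries it: the same change on two cores in this assay, a number 21 percentage points lower (beyond the scatter) from compound 1 to compound 2 and a number 3.5 percentage points lower (within the scatter) from compound 3 to compound 4, 17.5 percentage points apart, beyond the scatter of two such steps. Read the other way round, methyl in place of hydrogen on the nitro compounds gave a number 8.6 percentage points higher from compound 2 to compound 4 (within the scatter), and this step does not match the one seen on the chloro compounds either: the same change on two cores in this assay, a number 8.9 percentage points lower (within the scatter) from compound 1 to compound 3 and a number 8.6 percentage points higher (within the scatter) from compound 2 to compound 4, 17.5 percentage points apart, beyond the scatter of two such steps. The four compounds therefore show that neither change can simply be added to the other in this series, but they do not show why the two changes fail to add up, nor how either change would behave on any further core.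

The compounds shown leave open whether the same dependence on the core would appear with another group in place of chloro or nitro, such as an amine or a carboxylic acid, or with a second methyl elsewhere on the ring. They also leave open what a longer chain in place of the ketone-bearing chain would do to the inhibition, and whether the pattern would hold at any other dose.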